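Losing the second hydroxy on compound 1

This account rests on a few compounds, and the source may have more. Where it says the series, first, only, none or still open, it means among the compounds named here.

Measured in a functional assay, with a stated time of 30 min; a higher number here means a weaker inhibitor, a lower number a stronger inhibitor:
- compound 1 `Oc1ccc(O)c(/C=N/c2ccc(OCc3ccccc3)cc2)c1`: 21300 nM
- compound 2 `COc1ccc(O)c(/C=N/c2ccc(OCc3ccccc3)cc2)c1`: > 200000 nM (a limit)
- compound 3 `Oc1ccccc1/C=N/c1ccc(OCc2ccccc2)cc1`: > 200000 nM (a limit)

Of the three, compound 1 alone has a true number, 21300 nM. The other two values are limits of the assay.

Compound 4 `Cc1ccc(O)c(/C=N/c2ccc(OCc3ccccc3)cc2)c1` carries methyl in place of hydroxy on an aromatic carbon, turning 2,5-dihydroxyphenyl into 2-hydroxy-5-methylphenyl (methyl in place of hydroxy on an aromatic carbon). Two measured changes at that same carbon bear on it. Methoxy there gave an at least 9.3-fold higher number from compound 1 to compound 2 (0.97 log units; beyond the scatter), and hydrogen there gave an at least 9.3-fold higher number from compound 1 to compound 3 (0.97 log units; beyond the scatter). Both lie beyond the scatter, and compound 4 also lacks that hydroxy. A higher number of similar size is therefore expected in this assay, with a 9.4-fold higher number from compound 1 to compound 4 (0.97 log units; beyond the scatter) as the estimated step. Compound 4 is estimated at 200000 nM, with an expected range of 80000 nM to 500000 nM.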

Compound 4, half-maximal inhibitory concentration: > 200000 nM
Compound 4 gave a limit, no number; the forecaster's own chance of this, stated with the estimate: 75%; the middle value sits exactly at the limit.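

In this assay, methyl at this carbon gives an at least 9.3-fold higher number from compound 1 to compound 4 (0.97 log units; beyond the scatter). Methyl thus joins methoxy and hydrogen: all three replacements of the hydroxy end at a limit, and only compound 1 keeps a true number. The steps among compound 2, compound 3 and compound 4 cannot be read, because each of these compounds gives only a limit: the limit of > 200000 nM in this assay, at which 3 of the 4 values shown sit.

As far as these compounds go, whether an amine or a carboxylic acid at this carbon would keep a true number remains open. Also open, from the compounds shown here alone, is what the other hydroxy group, present in all four compounds, contributes.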